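Ethoxy for Methyl on the Aryl Ring: Cytotoxicity Notes

The source may hold more compounds than are shown below. What is called first, only, known or untested is meant among the compounds shown, and "the series" means these compounds.

Compound 1 `Cc1cccc(-c2cc(C(=O)N3CCC(Cc4ccccc4)CC3)c3ccccc3n2)c1` in an ADME assay on HepG2 2.2.15 cells (Homo sapiens) for cytotoxicity, read by MTT assay, with stated times of 3 days and 7 days (on this read-out lower numbers stand for higher toxicity in this test and higher numbers for lower toxicity in this test), gives > 20000 nM, which is a limit of the assay and not a number. Compound 2 `Cc1ccc(-c2cc(C(=O)N3CCC(Cc4ccccc4)CC3)c3ccccc3n2)cc1` gives > 20000 nM, again a limit. Compound 3 `O=C(c1cc(-c2cccc(Br)c2)nc2ccccc12)N1CCC(Cc2ccccc2)CC1` gives > 20000 nM, also a limit. Because of the limit of > 20000 nM in this assay, at which 3 of the 3 values shown sit, the steps a step that the two limits leave unreadable from compound 1 to compound 2, a step that the two limits leave unreadable from compound 1 to compound 3 and a step that the two limits leave unreadable from compound 2 to compound 3 cannot be read in size or direction; all three aryl variants sit at the same ceiling.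

Compound 4 `CCOc1cccc(-c2cc(C(=O)N3CCC(Cc4ccccc4)CC3)c3ccccc3n2)c1` differs from compound 1 by ethoxy in place of methyl on an aromatic carbon. The steps from compound 1 to compound 2 and from compound 1 to compound 3 alter the same aryl ring and bear on this change, yet each is unreadable, so the numbers give no direction for the new step. Nothing in the measured compounds points to a readable change, and the step of a number no higher from compound 1 to compound 4 (the limit leaves the size open) is expected to stay within scatter, most likely as another limit. Compound 4 is therefore estimated at 20000 nM, with a range from 10000 nM to 40000 nM.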

Compound 4, half-maximal cytotoxic concentration: > 20000 nM
Compound 4: a limit, no number (the forecaster's own chance of this, stated with the estimate: 85%); the middle value sits exactly at the limit.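

Compound 4 gives > 20000 nM, a limit and not a number. No step from compound 1, compound 2 or compound 3 to compound 4 can be read: the limit of > 20000 nM in this assay, at which 4 of the 4 values shown sit.

The compounds shown leave open whether these aryl variants differ at all in this assay.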